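This account rests on a few compounds, and the source may have more. Where it says the series, first, only, none or still open, it means among the compounds named here.

Within the data shown here, in a functional assay on A549 cells (Homo sapiens) for inhibition, read by sulforhodamine B assay, with a stated time of 72 h (on this read-out higher numbers stand for weaker inhibition and lower numbers for stronger inhibition), compound 1 `Nc1sc(-c2ccc(Cl)cc2)c(-c2ccc(Cl)cc2)c1C(=O)Nc1ccccc1` gives 25000 nM and compound 2 `Nc1sc(-c2ccc(Cl)cc2)c(-c2ccc(Cl)cc2)c1C(=O)NC1CC1` gives 1950 nM on the shared core, so compound 2 holds the lower of the two numbers so far. The next change leads to compound 3 `Nc1sc(-c2ccc(Cl)cc2)c(-c2ccc(Cl)cc2)c1C(=O)NC1CCCC1`: cyclopentyl in place of cyclopropyl on an amide-type nitrogen in all, that is, cyclopentyl in place of cyclopropyl on an amide-type nitrogen. Among the measured compounds shown here, only one measured step bears on this position: a 13-fold lower number from compound 1 to compound 2 (1.11 log units; beyond the scatter) for cyclopropyl in place of phenyl, a large step beyond the scatter. For the measured compounds named here, that single pair shows the group on this nitrogen can move the number, but no measured compound shows how ring size acts here. In this assay a small rise is expected, probably not beyond the scatter: a 1.8-fold higher number from compound 2 to compound 3 (0.25 log units; within the scatter) is the estimated step here. For compound 3 the estimated value is 3500 nM with an expected range of 1000 nM to 14000 nM overall.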

Compound 3, half-maximal inhibitory concentration: 6790 nM
Compound 3: the middle estimate sits 1.9-fold (0.29 log units) below what was measured; measured number inside the range.
By their numbers in this assay, from the lowest: compound 2; then compound 3; then compound 1.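

In this assay the size of the non-aromatic ring on the amide-type nitrogen proves to count, with a 3.5-fold higher number from compound 2 to compound 3 (0.54 log units; beyond the scatter) for cyclopentyl in place of cyclopropyl. Cyclopentyl still keeps part of the gain over phenyl, with a 3.7-fold lower number from compound 1 to compound 3 (0.57 log units; beyond the scatter) and so the three groups on this nitrogen now order from the lowest number as cyclopropyl, cyclopentyl, phenyl. No measurement at hand explains this order.

Two non-aromatic rings cannot show whether the number rises steadily with ring size, and cyclobutyl or cyclohexyl on the same nitrogen would test that. On these data alone, open-chain groups such as ethyl or isopropyl, and a ring carrying a hydroxyl or an amine, also remain open at this position.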